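Trimming an isopropoxy to an ethoxy on a triazole scaffold

The source may hold more compounds than are shown below. What is called first, only, known or untested is meant among the compounds shown, and "the series" means these compounds.

Going by the values given here, compound 1 `COc1cc(-n2ncnc2-c2ccc(OC(C)C)cc2)cc(OC)c1OC` is the only member of this small set that gives a number in a functional assay on HL-60 cells (Homo sapiens) for antiproliferative activity, read by MTT assay, with a stated time of 72 h (on this read-out lower numbers stand for stronger inhibition and higher numbers for weaker inhibition), where compound 1 reaches 700 nM. Its companion compound 2 `COc1cc(-c2ncnn2-c2cccc([N+](=O)[O-])c2)cc(OC)c1OC` returns only a limit of the assay in this assay, with compound 2 recorded as > 10000 nM, a boundary described as the limit of > 10000 nM in this assay, at which 1 of the 2 values shown sits, rather than a measured value. Among the compounds with values here, because no two measured compounds differ in a single place, no measured step exists here to calibrate the one now under consideration.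

Compound 3 `CCOc1ccc(-c2ncnn2-c2cc(OC)c(OC)c(OC)c2)cc1` shares the core of compound 1 and differs from it by hydrogen in place of methyl on a saturated chain carbon bound to an oxygen on an aromatic ring and a saturated chain carbon. The alkyl chain on the aryl ether is shortened, nothing else moves, and no charge, donor or acceptor is added or lost.

Within the data shown here, with no measured step of this kind to lean on, the step from compound 1 to compound 3 is expected to stay within the usual scatter of this assay, as a 1.2-fold lower number from compound 1 to compound 3 (0.07 log units; within the scatter). Compound 3 is therefore estimated at 600 nM, with a range from 200 nM to 2000 nM.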

Compound 3, half-maximal inhibitory concentration: 20 nM
Beside the measured number, compound 3's estimate is 30-fold (1.48 log units) above it; the measured number lies below the stated range.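

In this assay, going by these compounds alone, the change from isopropoxy to ethoxy gives the first measured step in this set, a 35-fold lower number from compound 1 to compound 3 (1.54 log units; beyond the scatter), and it is large. This shows that the place on a saturated chain carbon bound to an oxygen on an aromatic ring responds strongly to the loss of one methyl, even though no charge, donor or acceptor enters or leaves and the shared core stays the same. The data shown hold no measurement that bears on why this step is so large.

A single step cannot show whether the number would keep falling as the chain shortens, or whether a methoxy, a hydroxyl or a longer chain such as propoxy in place of the ethoxy would compare with compound 3 at 20 nM. Within the data shown here, compound 2 stands only at a limit of the assay, > 10000 nM, and it differs from compound 1 and compound 3 in more than one place, so it adds no step at this position.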